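A few compounds are considered here, and "the series" means these few. Any claim that something is new, unique, unknown or untested is made for them only; others in the source may bear on it.

Measured in a physicochemical assay for solubility, read by LC-MS, in phosphate buffer, with a stated time of 24 h, at pH 7.4; a higher number here means a more soluble compound, a lower number a less soluble compound:
- compound 1 `Cc1nc(CN(C)C)ccc1-c1cnc(NCc2c(F)ccc3c2CCO3)c2cn[nH]c(=O)c12`: > 1000000 nM, a limit
- compound 2 `Cc1ncccc1-c1cnc(NCc2c(F)ccc3c2CCO3)c2cn[nH]c(=O)c12`: < 2000 nM, a limit
- compound 3 `CNC(=O)c1ccc(-c2cnc(NCc3c(F)ccc4c3CCO4)c3cn[nH]c(=O)c23)c(C)n1`: 19000 nM

Of these three compounds, only compound 3 has an actual number, 19000 nM. The other two results are limits. The next compound, compound 4 `CN(c1ccn(C)n1)c1cnc(NCc2c(F)ccc3c2CCO3)c2cn[nH]c(=O)c12`, keeps the shared core but replaces the whole 2-methyl-6-(methylcarbamoyl)pyridin-3-yl group with methyl(1-methyl-1H-pyrazol-3-yl)amino: methyl(1-methyl-1H-pyrazol-3-yl)amino in place of 2-methyl-6-(methylcarbamoyl)pyridin-3-yl on an aromatic carbon.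

Among the measured compounds shown here, no measured step covers this exchange directly, so the evidence is indirect. The closest comparison is the loss of methylcarbamoyl, since the step in the opposite direction was at least modest, an at least 9.5-fold higher number from compound 2 to compound 3 (0.97 log units; beyond the scatter). The two large steps, an at least 500-fold lower number from compound 1 to compound 2 (2.69 log units; beyond the scatter) and an at least 52-fold lower number from compound 1 to compound 3 (1.72 log units; beyond the scatter), both start from the (dimethylamino)methyl group of compound 1. Compound 4 has no such group, so a rise of that size is not expected in this assay. A small or moderate fall from compound 3 seems most likely, partly reversing an at least 9.5-fold higher number from compound 2 to compound 3 (0.97 log units; beyond the scatter), but the entering group has not been tested in any measured compound. The estimated step is a 2.4-fold lower number from compound 3 to compound 4 (0.38 log units; beyond the scatter). For compound 4 the estimated value is 8000 nM, with an expected range from 2000 nM to 30000 nM.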

Compound 4, solubility: 12000 nM
Beside the measured number, compound 4's estimate is 1.5-fold (0.18 log units) below it; low and high end bracket the measured number.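

In this assay, replacing the pyridine-based group with a five-membered aromatic ring that carries no hydrogen-bond donors gives a 1.6-fold lower number from compound 3 to compound 4 (0.20 log units; within the scatter). Within the scatter of this assay, methyl(1-methyl-1H-pyrazol-3-yl)amino and 2-methyl-6-(methylcarbamoyl)pyridin-3-yl therefore cannot be told apart at this position, which shows that methylcarbamoyl on a pyridine is not the only group here to give a measured number in this range. Replacing 2-methylpyridin-3-yl with the same group gives an at least 6.0-fold higher number from compound 2 to compound 4 (0.77 log units; beyond the scatter), a step that starts from a limit and not from a number: the limit of < 2000 nM in this assay, at which 1 of the 4 values shown sits. Replacing 6-((dimethylamino)methyl)-2-methylpyridin-3-yl gives an at least 83-fold lower number from compound 1 to compound 4 (1.92 log units; beyond the scatter), a step that also starts from a limit and not from a number: the limit of > 1000000 nM in this assay, at which 1 of the 4 values shown sits.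

As far as these compounds go, it remains open whether a (dimethylamino)methyl group or a carboxylic acid on the pyrazole ring would move the number in this assay away from that of compound 4. Also open, from the compounds shown here alone, is how much of that number depends on the methyl group on the linking nitrogen, which a simple secondary amine at the same place would test.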